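Adding One Bromo Group to Compound 3

A few compounds are considered here, and "the series" means these few. Any claim that something is new, unique, unknown or untested is made for them only; others in the source may bear on it.

Compound 1 `CCOc1cc2occ(-c3csc4ccccc34)c(=O)c2c(OCC)c1OC`: 2600 nM
Compound 2 `CCOc1c(OC)cc2occ(-c3csc4ccccc34)c(=O)c2c1OC`: 4800 nM
Compound 3 `O=C(/C=C/c1csc2ccccc12)c1ccccc1O`: 5300 nM

All three numbers come from a functional assay on A549 cells (Homo sapiens) for antiproliferative activity, read by sulforhodamine B assay, with a stated time of 72 h; a higher number here means a weaker inhibitor, a lower number a stronger inhibitor. Compound 3 gives 5300 nM and stands at the weak end of this small set, together with compound 2. The number for compound 2, 4800 nM, lies within the usual scatter of compound 3, so the two cannot be told apart. Compound 1, at 2600 nM, has a lower number than compound 3, and the gap lies just beyond the scatter.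

Compound 4 `O=C(/C=C/c1csc2ccccc12)c1cc(Br)ccc1O` has not been measured yet. It is compound 3 with bromo in place of hydrogen on an aromatic carbon, para to a hydroxy group: bromo in place of hydrogen on an aromatic carbon.

Among the compounds with values here, no pair of measured compounds shows this kind of change on its own, so the data offer no direct guide. Compound 1 at 2600 nM and compound 3 at 5300 nM differ widely in structure yet remain close in number, which suggests that a single added atom will not move the value far. In this assay, the expected change is small and towards a stronger inhibitor: a 1.7-fold lower number from compound 3 to compound 4 (0.22 log units; within the scatter). For compound 4 the estimated value is 3200 nM, with an expected range from 1200 nM to 8000 nM.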

Compound 4, half-maximal inhibitory concentration: 660 nM
Beside the measured number, compound 4's estimate is 4.8-fold (0.69 log units) above it, and the stated range ends above it.
By their numbers in this assay, from the lowest: compound 4; then compounds 1, 2 and 3 (each within the scatter of the next, the first and the last beyond it).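

In this assay a single bromo on an aromatic carbon, para to a hydroxy group, gives an 8.0-fold lower number from compound 3 to compound 4 (0.90 log units; beyond the scatter) and so shows that this place on the six-membered aromatic ring of carbon only is not indifferent to what stands on it. Within the data shown here, this is the only step here in which two measured compounds differ in one place, and it shows that replacing a hydrogen with one heavy atom, with no ring, no hydrogen-bond donors or acceptors and no net charge, can move the number well beyond the usual scatter. Nothing measured here speaks to what lies behind this step.

With only bromo shown at this place, it remains open whether chloro, an amine or a carboxylic acid on the same aromatic carbon would move the number in the same direction, or whether the step is particular to bromo. On these data alone, it also remains open whether bromo on another carbon of this ring, or on the same kind of carbon in the core of compound 1, would give a step of similar size.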